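A few compounds are considered here, and "the series" means these few. Any claim that something is new, unique, unknown or untested is made for them only; others in the source may bear on it.

Of the compounds shown here, two built on the same core have been tested so far in a functional assay on MCF cells (Homo sapiens) for antiproliferative activity, with a stated time of 72 h; a lower number here means a stronger inhibitor, a higher number a weaker inhibitor. Compound 1, `OC[C@H]1O[C@@H](n2cnc3c(NCc4ccc(F)cc4F)ncnc32)[C@H](O)[C@@H]1O`, gives > 166000 nM, which is a limit of the assay and not a number. Compound 2, `OC[C@H]1O[C@@H](n2cnc3c(NCc4cc(O)cc(O)c4)ncnc32)[C@H](O)[C@@H]1O`, gives > 166000 nM, which is also a limit and not a number. So compound 2 has no exact value, and the picture so far is simply (the limit of > 166000 nM in this assay, at which 2 of the 2 values shown sit).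

Compound 3, `Cc1cccc(CNc2ncnc3c2ncn3[C@@H]2O[C@H](CO)[C@@H](O)[C@H]2O)c1O`, changes only the group carried on the chain of compound 2: 2-hydroxy-3-methylphenyl in place of 3,5-dihydroxyphenyl on a saturated chain carbon bound to a nitrogen on an aromatic ring. Among the measured compounds shown here, the one measured step that bears on this is a step that the two limits leave unreadable from compound 1 to compound 2. It changes the same place on the shared core, but it offers no size to carry over.

The expectation is therefore loose. Compound 3 may stop at the same limit, but if this assay returns a number, it is expected to show a stronger inhibitor. For compound 3 the estimated value is 40000 nM, with an expected range from 3000 nM to 166000 nM. This estimate corresponds to an expected at least 4.1-fold lower number from compound 2 to compound 3 (0.61 log units; beyond the scatter).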

Compound 3, half-maximal inhibitory concentration: 6900 nM
Beside the measured number, compound 3's estimate is 5.8-fold (0.76 log units) above it; low and high end bracket the measured number.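

In this assay, among the compounds shown here, compound 3 is the first compound here to return a real number and not a limit, which shows that the group on this saturated chain carbon can move the read-out on an otherwise unchanged core. Replacing 3,5-dihydroxyphenyl with 2-hydroxy-3-methylphenyl gives an at least 24-fold lower number from compound 2 to compound 3 (1.38 log units; beyond the scatter), and replacing 2,4-difluorophenyl with the same group gives an at least 24-fold lower number from compound 1 to compound 3 (1.38 log units; beyond the scatter), so both steps are large and the new group outperforms two quite different rings. Each of these sizes is only a minimum, as the starting point of each step is a limit and not a number, and that limit still holds most of the set: the limit of > 166000 nM in this assay, at which 2 of the 3 values shown sit.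

Whether the gain belongs to the hydroxy or to the methyl of the 2-hydroxy-3-methylphenyl group stays open, as the two appear only together in the compounds shown. Also open, on these data alone, is how an amine or a methoxy in place of that hydroxy, or a longer chain between the ring and the nitrogen, would read in this assay.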